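The compounds below may be only part of what the source reports. "The series", "measured", "known", "first", "only" and "open" are said of these compounds alone.

Of the compounds shown here, three sharing one core have been tested in a functional assay on the whole organism with Mus musculus as the target, in the maximal electroshock model, with a stated time of 120 min; on this read-out lower numbers stand for an effect already at smaller amounts and higher numbers for an effect only at larger amounts of compound. Compound 1 `CCCc1cccc(N2CCNCC2)n1` gives 10 mg/kg. Compound 2 `CCCCCCCc1cccc(N2CCNCC2)n1` gives 10 mg/kg. Compound 3 `CCCCCCCCCc1cccc(N2CCNCC2)n1` gives 10 mg/kg. Compound 2 differs from compound 1 by butyl in place of hydrogen on a saturated chain carbon, three bonds along the chain from an aromatic carbon, and the step it made was no change at the digits printed from compound 1 to compound 2 (within the scatter). Compound 3 differs from compound 1 by hexyl in place of hydrogen on a saturated chain carbon, three bonds along the chain from an aromatic carbon, and that step was no change at the digits printed from compound 1 to compound 3 (within the scatter); the step of no change at the digits printed from compound 2 to compound 3 (within the scatter) is likewise flat.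

Compound 4 `CCCCCCC(CCCCCC)c1cccc(N2CCNCC2)n1` has not yet been measured. It differs from compound 2 by hexyl in place of hydrogen on a saturated chain carbon bound to an aromatic carbon and a saturated chain carbon. Going by the values given here, this is the same kind of change as the one from compound 1 to compound 3, but the place differs: there the hexyl entered three bonds along the chain from an aromatic carbon, whereas here it enters on a saturated chain carbon bound to an aromatic carbon and a saturated chain carbon. Because lengthening the chain gave no change at the digits printed from compound 1 to compound 3 (within the scatter), the step from compound 2 to compound 4 in this assay is expected to be no change at the digits printed from compound 2 to compound 4 (within the scatter). Compound 4 is therefore estimated at 10 mg/kg, with a range from 3 mg/kg to 30 mg/kg.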

Compound 4, minimum effective dose: > 300 mg/kg
Compound 4 ended at the assay's limit; the forecaster's own chance of this, stated with the estimate: 10%; at least 30-fold (1.47 log units) between middle value and limit.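

Hexyl in place of hydrogen on a saturated chain carbon bound to an aromatic carbon and a saturated chain carbon gave an at least 30-fold higher number from compound 2 to compound 4 (1.47 log units; beyond the scatter), whereas hexyl three bonds along the chain from an aromatic carbon gave no change at the digits printed from compound 1 to compound 3 (within the scatter), so in this assay this change does not carry over unaltered from one core to the other: the same change on two cores in this assay, no change at the digits printed (within the scatter) from compound 1 to compound 3 and an at least 30-fold higher number (1.47 log units; beyond the scatter) from compound 2 to compound 4, at least 30-fold (1.47 log units) apart, beyond the scatter of two such steps

The value of compound 4, > 300 mg/kg, is a limit of the assay and not a number: the limit of > 300 mg/kg in this assay, at which 1 of the 4 values shown sits.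

This single pair of steps does not show whether the place of the hexyl, the heptyl-length chain already on compound 2, or something else lies behind the difference, and it gives no rule for other cores.

The compounds shown leave open whether a methyl or an ethyl on that same carbon would give a value like that of compound 2, and so at what size the change begins to matter. They also leave open what an amine or a carboxylic acid in place of the hexyl on that carbon would do.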